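Tetrazole to methyl-oxadiazole on the thiophene of compound 2

The source may hold more compounds than are shown below. What is called first, only, known or untested is meant among the compounds shown, and "the series" means these compounds.

Measured so far in a functional assay (Pituitary gland cell) with Rattus norvegicus as the target; on this read-out higher numbers stand for an effect only at larger amounts of compound and lower numbers for an effect already at smaller amounts:
compound 1 `Cn1ncnc1-c1ccccc1-c1ccc(CN2C(=O)[C@H](NC(=O)CC(C)(C)N)CCc3ccccc32)cc1` gives 265 nM
compound 2 `CC(C)(N)CC(=O)N[C@@H]1CCc2ccccc2N(Cc2ccc(-c3sccc3-c3nn[nH]n3)cc2)C1=O` gives 140 nM

Compound 2 holds the lower of the two numbers, but the gap to compound 1 is within the scatter: the step of a 1.9-fold lower number from compound 1 to compound 2 (0.28 log units; within the scatter) does not separate the two compounds. Compound 3 `Cc1nnc(-c2cscc2-c2ccc(CN3C(=O)[C@H](NC(=O)CC(C)(C)N)CCc4ccccc43)cc2)o1` is not yet measured. It differs from compound 2 in one place: 4-(5-methyl-1,3,4-oxadiazol-2-yl)thiophen-3-yl in place of 3-(2H-tetrazol-5-yl)thiophen-2-yl on an aromatic carbon. The group that leaves carries 1 hydrogen-bond donor, the group that enters has 0 hydrogen-bond donors; the acceptor count is unchanged.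

Among the compounds with values here, only one measured step bears on this region, the exchange of the aryl group on the same aromatic carbon from compound 1 to compound 2, and it stayed within the scatter. Within the data shown here, no measured pair shows what removing the tetrazole itself does, so the single step gives weak guidance. The expectation for compound 3 is a step of a 2.3-fold higher number from compound 2 to compound 3 (0.36 log units; beyond the scatter), towards a somewhat higher number but with wide uncertainty. Compound 3 is therefore estimated at 320 nM, with a range from 100 nM to 1300 nM.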

Compound 3, half-maximal effective concentration: 125 nM
Estimate against measurement, compound 3: 2.6-fold (0.41 log units) above; the range from low to high includes it.
By their numbers in this assay, from the lowest: compounds 3, 2 and 1 (each within the scatter of the next, the first and the last beyond it).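

In this assay, the change on the aromatic carbon gives a 1.1-fold lower number from compound 2 to compound 3 (0.05 log units; within the scatter). A tetrazole hydrogen-bond donor is therefore not needed to hold the number here, although this step also changes the thiophene attachment named in the two groups and so does not isolate the donor. Within the data shown here, compound 3 also provides the first step in this set that lies beyond the scatter, a 2.1-fold lower number from compound 1 to compound 3 (0.33 log units; beyond the scatter), whereas compound 2 is not separated from compound 1; this step is modest, and it replaces 2-(1-methyl-1H-1,2,4-triazol-5-yl)phenyl as a whole, so no single feature of the entering 4-(5-methyl-1,3,4-oxadiazol-2-yl)thiophen-3-yl group can be credited with it, and no measurement is available to explain the result.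

Still open, from the compounds shown here alone, is what a carboxylic acid or a nitrile would give in place of the five-membered ring with hetero atoms on the thiophene in this assay. The contribution of the methyl on the oxadiazole and the effect of the thiophene attachment taken alone also remain unresolved.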